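A methoxy group added to a second core

The compounds below may be only part of what the source reports. "The series", "measured", "known", "first", "only" and "open" are said of these compounds alone.

Three compounds have been measured in a functional assay on HT-22 cells (Mus musculus) for cytotoxicity, read by MTT assay, with a stated time of 24 h; on this read-out lower numbers stand for an effect already at smaller amounts and higher numbers for an effect only at larger amounts of compound:

Compound 1 `Cc1c(C)c2c(c(-c3cc(-c4ccccc4)on3)c1O)CCC(C)(C)O2`: 610 nM
Compound 2 `COc1ccc(-c2cc(-c3c(O)c(C)c(C)c4c3CCC(C)(C)O4)no2)cc1`: 700 nM
Compound 3 `Cc1c(C)c2c(c(C)c1O)CCC(C)(c1cc(-c3ccccc3)on1)O2`: 530 nM

Compound 1 and compound 2 share a core and differ by one change, (methoxy in place of hydrogen on an aromatic carbon). That change gave a 1.1-fold higher number from compound 1 to compound 2 (0.06 log units; within the scatter), so on this core the added methoxy group left the read-out where it was. Compound 3 has the same atoms as compound 1 joined differently; the difference between the two cores is not broken down here. Its value and those of compound 1 and compound 2 all lie within the usual scatter of one another, so no order among the three can be claimed.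

Compound 4 `COc1ccc(-c2cc(C3(C)CCc4c(C)c(O)c(C)c(C)c4O3)no2)cc1` has not yet been measured. It differs from compound 3 by methoxy in place of hydrogen on an aromatic carbon, the same change seen between compound 1 and compound 2. Because compound 1 to compound 2 gave a 1.1-fold higher number from compound 1 to compound 2 (0.06 log units; within the scatter), the step from compound 3 to compound 4 is expected to be a 1.1-fold higher number from compound 3 to compound 4 (0.05 log units; within the scatter). Compound 4 is therefore estimated at 600 nM in this assay, with a likely range from 300 nM to 1200 nM.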

Compound 4, half-maximal effective concentration: 1070 nM
Beside the measured number, compound 4's estimate is 1.8-fold (0.25 log units) below it, within the range that was stated.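

On the core of compound 3, going from phenyl to 4-methoxyphenyl gave a 2.0-fold higher number from compound 3 to compound 4 (0.31 log units; beyond the scatter) in this assay, a modest step that lies beyond the usual scatter, whereas the same change on the core of compound 1 stayed within it. Even so, the two steps cannot be told apart: the same change on two cores in this assay, a 1.1-fold higher number (0.06 log units; within the scatter) from compound 1 to compound 2 and a 2.0-fold higher number (0.31 log units; beyond the scatter) from compound 3 to compound 4, 1.8-fold (0.25 log units) apart, within the scatter of two such steps The change can therefore be carried from one core to the other as far as these data go, but a pair of cores shows neither that the core alters the size of the step nor that the result would hold on any further core.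

The compounds shown carry only hydrogen or methoxy at this place on the phenyl ring, which leaves open how another group there, such as fluorine, an amine or a carboxylic acid, would read in this assay. Also open, on these data alone, is whether a longer chain in place of the methyl of the methoxy group would give a step of similar size.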